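The source may report more compounds than this note shows. Statements on the series, on what has been measured and on what is new or still open speak of the compounds shown alone.

Measured so far:
Compound 1, `CCCSc1nc(N[C@@H]2C[C@H]2c2ccc(F)c(F)c2)c2nnn([C@@H]3C[C@H](OCCOC(=O)OCC)[C@@H](O)[C@H]3O)c2n1`: 47.7%
Compound 2, `CCCSc1nc(N[C@@H]2C[C@H]2c2ccc(F)c(F)c2)c2nnn([C@@H]3C[C@H](OC(=O)OCC)[C@@H](O)[C@H]3O)c2n1`: 42.6%

The account concerns the read-out of a functional assay on the whole organism (strain Sprague-Dawley) for inhibition, with Rattus norvegicus as the target, with a stated time of 0.5 h, at a dose of 5 mg/kg by the oral route (a higher number here means more inhibition at the dose given (going by the name of the read-out), a lower number less inhibition), and follows one step away from compound 1. Compound 1 holds the highest of the two numbers obtained, and its nearest neighbour is compound 2, reached by a number 5.1 percentage points lower from compound 1 to compound 2 (within the scatter). The two values therefore sit within the scatter of each other, and no order between them can be claimed.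

The compound not yet measured is compound 3, `CCCSc1nc(N[C@@H]2C[C@H]2c2ccc(F)c(F)c2)c2nnn([C@@H]3C[C@H](OC(=O)OCC(C)C)[C@@H](O)[C@H]3O)c2n1`. It differs from compound 1 in one place: a group of 7 heavy atoms (5 carbon, 2 oxygen; no ring) in place of a group of 8 heavy atoms (5 carbon, 3 oxygen; no ring), on an oxygen on a saturated carbon. Among the compounds with values here, the only measured step that bears on this change is the one from compound 1 to compound 2, which also replaces the same group on the same oxygen and which stayed within the scatter. On that evidence alone, compound 3 is expected to show no step beyond the scatter, so the expected step is a number 2.7 percentage points lower from compound 1 to compound 3 (within the scatter). Compound 3 is thus estimated at 45%, with a range from 30% to 60% expected to cover most repeat measurements.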

Compound 3, a percentage reported as inhibition, in the whole organism at one dose (the size of the read-out at that dose, not a potency): 13.2%
Compound 3: the middle estimate sits 31.8 percentage points above what was measured; the whole stated range lies above it.
By their numbers in this assay, from the lowest: compound 3; then compounds 2 and 1 (each within the scatter of the next).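

In this assay, the group on this oxygen turns out not to be freely interchangeable: with isobutoxycarbonyl entering, the result is a number 34.5 percentage points lower from compound 1 to compound 3 (beyond the scatter). The closest comparison is the one with isopropyl in place of methyl on a saturated chain carbon bound to an oxygen next to a carbonyl group, which gives a number 29.4 percentage points lower from compound 2 to compound 3 (beyond the scatter), so a change confined to the chain of this group is enough to move the read-out beyond the scatter, whereas the earlier pair of compounds had shown no such separation. Nothing available on these compounds accounts for this drop.

The compounds shown leave open whether the branching of the chain matters or only its size, since an unbranched n-butyl chain or a cyclopropyl group at the same place would be needed to tell these apart. Also open, as far as these compounds go, is how a free hydroxyl on this oxygen, or a chain ending in an amine, would read in this assay, and whether the separation seen here would hold at another dose or time.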